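Carboxyphenyl swap on the isobutyl ketone core

This account rests on a few compounds, and the source may have more. Where it says the series, first, only, none or still open, it means among the compounds named here.

Working notes on a set of four aryl ketone ethers with a terminal carboxyphenoxy group, read in an assay on HEK293 cells for positive allosteric modulation of metabotropic glutamate receptor 3 (Rattus norvegicus), read by thallium flux, with a stated time of 2.5 min; a lower number here means a smaller maximal response, a higher number a larger maximal response. Compound 1 `Cc1c(OCCCCOc2ccccc2C(=O)O)ccc(C(=O)CC2CCCC2)c1C` gives 28%. Compound 2 `Cc1c(OCCCCOc2ccc(F)c(C(=O)O)c2)ccc(C(=O)CC(C)C)c1C` gives 13.8%. Compound 3 `Cc1c(OCCCCOc2ccc(F)c(C(=O)O)c2)ccc(C(=O)CC2CCCC2)c1C` gives 12.6%. Compound 4 `Cc1c(OCCCCOc2ccccc2C(=O)O)ccc(C(=O)CC(C)C)c1C` has not yet been measured in this assay.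

Compounds 2 and 3 differ in the core only: isopropyl in place of cyclopentyl on a saturated chain carbon bound to a carbonyl carbon. The matching step, a number 1.2 percentage points lower from compound 2 to compound 3 (within the scatter), lies within the scatter, so the two cores behave alike as far as these two numbers show.

Compounds 3 and 1 share the core of compound 3 and differ in the terminal aryl group: 2-carboxyphenyl in place of 3-carboxy-4-fluorophenyl on an oxygen on a saturated carbon. Within the data shown here, this change gives a number 15.4 percentage points higher from compound 3 to compound 1 (beyond the scatter), a modest rise beyond the scatter and the only change in the set that moves the read-out.

The same change on the core of compound 2 leads to compound 4: 2-carboxyphenyl in place of 3-carboxy-4-fluorophenyl on an oxygen on a saturated carbon. The place of the change is the same in both pairs, so this is the same change, made once on each core.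

With the two cores giving numbers within the scatter of each other, the step from compound 2 to compound 4 is expected to match the earlier one, a number 15.2 percentage points higher from compound 2 to compound 4 (beyond the scatter), resting on the measured step of a number 15.4 percentage points higher from compound 3 to compound 1 (beyond the scatter). A single precedent supports this, so the range is kept wide. Compound 4 is therefore estimated at 29% in this assay, between 17% and 41%.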

Compound 4, largest response reached (reported as percent of maximum), in percent of the reference or control that the assay uses: 30.7%
Compound 4: middle estimate off by 1.7 percentage points, on the low side; measured number inside the range.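

On the two cores shown, the change to 2-carboxyphenyl in place of 3-carboxy-4-fluorophenyl carries over intact: in this assay it gives a number 16.9 percentage points higher from compound 2 to compound 4 (beyond the scatter) on the isopropyl side, and the two steps agree: the same change on two cores in this assay, a number 15.4 percentage points higher (beyond the scatter) from compound 3 to compound 1 and a number 16.9 percentage points higher (beyond the scatter) from compound 2 to compound 4, 1.5 percentage points apart, within the scatter of two such steps. The reverse reading holds as well, since isopropyl in place of cyclopentyl gives a number 2.7 percentage points higher from compound 1 to compound 4 (within the scatter) and leaves the read-out unmoved on either terminal aryl group: the same change on two cores in this assay, a number 1.2 percentage points lower (within the scatter) from compound 2 to compound 3 and a number 2.7 percentage points lower (within the scatter) from compound 4 to compound 1, 1.5 percentage points apart, within the scatter of two such steps. This shows that the two changes behave independently across these four compounds, but it rests on one pair of closely related cores in this assay, so it does not show that the aryl step would hold on a core with a different ketone side chain, nor does it give any reason for the step.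

The aryl change also alters two things at once, so 3-carboxyphenyl and 2-carboxy-4-fluorophenyl groups would be needed to tell the loss of the fluorine from the move of the carboxylic acid. Also open, going by these compounds, is how the step behaves with a tetrazole in place of the carboxylic acid, with a longer chain between the two ether oxygens, or with a phenyl group on the ketone side chain.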